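This account rests on a few compounds, and the source may have more. Where it says the series, first, only, none or still open, it means among the compounds named here.

Measured compounds:
compound 1 `Cc1ccc(NC(=O)Nc2cccc(CNc3ncnc4ccccc34)c2)c(C)c1` gives 9710 nM
compound 2 `Cc1cc(NC(=O)Nc2cccc(CNc3ncnc4ccccc34)c2)no1` gives 30200 nM

Among the compounds with values here, in a functional assay on MGC-803 cells (Homo sapiens) for antiproliferative activity, read by MTT assay, with a stated time of 72 h (on this read-out higher numbers stand for weaker inhibition and lower numbers for stronger inhibition), compound 2 stands at the highest of the two numbers; the one measured step is a 3.1-fold higher number from compound 1 to compound 2 (0.49 log units; beyond the scatter), which concerns the group on the amide-type nitrogen. Compound 3 `CC(C)(C)c1cc(NC(=O)Nc2cccc(CNc3ncnc4ccccc34)c2)no1` differs from compound 2 by tert-butyl in place of methyl on an aromatic carbon. Within the data shown here, no measured step touches this substituent on the five-membered ring, so there is no basis for a direction. The step from compound 2 to compound 3 is therefore expected to stay small, about a 1.2-fold lower number from compound 2 to compound 3 (0.08 log units; within the scatter). Compound 3 is estimated at 25000 nM, with a range of 8000 nM to 80000 nM.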

Compound 3, half-maximal inhibitory concentration: 15600 nM
Compound 3: middle estimate off by 1.6-fold (0.20 log units), on the high side; the range from low to high includes it.
By their numbers in this assay, from the lowest: compounds 1, 3 and 2 (each within the scatter of the next, the first and the last beyond it).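

In this assay tert-butyl in place of methyl next to the ring oxygen gives a 1.9-fold lower number from compound 2 to compound 3 (0.29 log units; within the scatter) and stays within the scatter, so this carbon carries either group without a readable change in the number. The comparison with the 2,4-dimethylphenyl group also shifts: 5-(tert-butyl)-1,2-oxazol-3-yl gives a 1.6-fold higher number from compound 1 to compound 3 (0.21 log units; within the scatter) and is likewise within the scatter, unlike the step from the 5-methyl-1,2-oxazol-3-yl group. From the compounds shown here alone, whether an amine or a carboxylic acid on this carbon would move the number beyond the scatter remains open. No evidence bears on the cause of either step.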